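This account rests on a few compounds, and the source may have more. Where it says the series, first, only, none or still open, it means among the compounds named here.

Compound 3 `C=CC(=O)Nc1cc(Nc2ncc(C#N)c(-c3cn(C)c4ccc(F)cc34)n2)c(OC)cc1N(C)CCN(C)C` stands at the top of the three numbers obtained so far: in a functional assay on NCI-H1975 cells (Homo sapiens) for antiproliferative activity, read by MTT assay, with a stated time of 72 h (on this read-out lower numbers stand for stronger inhibition and higher numbers for weaker inhibition), compound 3 gives 11400 nM. Compound 1 `C=CC(=O)Nc1cc(Nc2nccc(-c3cn(C)c4ccc(F)cc34)n2)c(OC)cc1N(C)CCN(C)C` gives 254 nM in this assay, and compound 2 `COc1cc(N(C)CCN(C)C)c(NC(=O)/C=C\C(C)C)cc1Nc1nccc(-c2cn(C)c3ccc(F)cc23)n1` gives 7360 nM; compound 2 and compound 3 lie within the scatter of each other, while the move from compound 1 to compound 3 is a 45-fold higher number from compound 1 to compound 3 (1.65 log units; beyond the scatter).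

Compound 4 `COc1cc(N(C)CCN(C)C)c(NC(=O)/C=C\C(C)C)cc1Nc1ncc(C#N)c(-c2cn(C)c3ccc(F)cc23)n1` differs from compound 3 in one place: 3-methylbut-1-en-1-yl in place of vinyl on a carbonyl carbon. The same exchange has been seen once before, on the shared core without the cyano group, where the step from compound 1 to compound 2 was a 29-fold higher number from compound 1 to compound 2 (1.46 log units; beyond the scatter). That step bears directly on the present one. A shift of comparable size, upward, is therefore expected from compound 3 to compound 4, namely a 13-fold higher number from compound 3 to compound 4 (1.12 log units; beyond the scatter). Compound 4 is accordingly expected to give about 150000 nM in this assay, with a range of 40000 nM to 600000 nM, and a fair chance that only a limit is reported.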

Compound 4, half-maximal inhibitory concentration: 1130 nM
The estimate for compound 4 lay 130-fold (2.12 log units) above the measured number; measured number outside the range, below it.
By their numbers in this assay, from the lowest: compound 1; then compound 4; then compounds 2 and 3 (each within the scatter of the next).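

On the core carrying the cyano group, 3-methylbut-1-en-1-yl in place of vinyl on a carbonyl carbon gives a 10-fold lower number from compound 3 to compound 4 (1.00 log units; beyond the scatter) in this assay, so this exchange does not carry a fixed direction from one core to the other: the same change on two cores in this assay, a 29-fold higher number (1.46 log units; beyond the scatter) from compound 1 to compound 2 and a 10-fold lower number (1.00 log units; beyond the scatter) from compound 3 to compound 4, 290-fold (2.47 log units) apart, beyond the scatter of two such steps. Introducing the cyano group on an aromatic carbon likewise reverses direction when the group on the carbonyl carbon is 3-methylbut-1-en-1-yl, giving a 6.5-fold lower number from compound 2 to compound 4 (0.81 log units; beyond the scatter): the same change on two cores in this assay, a 45-fold higher number (1.65 log units; beyond the scatter) from compound 1 to compound 3 and a 6.5-fold lower number (0.81 log units; beyond the scatter) from compound 2 to compound 4, 290-fold (2.47 log units) apart, beyond the scatter of two such steps. Across these four compounds, neither change can therefore be read apart from the other.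

From the compounds shown here alone, it remains open whether this reversal is particular to the cyano group or would also appear with a chlorine atom or an amine on that aromatic carbon. Going by these compounds, it is equally open how a shorter prop-1-en-1-yl chain or a longer alkenyl chain on the carbonyl carbon would behave on either core.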